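Amide variation on a shared core against SK-BR-3 cells

The source may hold more compounds than are shown below. What is called first, only, known or untested is meant among the compounds shown, and "the series" means these compounds.

Measured compounds:
compound 1 `CCc1ccc(C(=O)Nc2ccc3nc(N4CCN(CC)CC4)cc(C)c3c2)cc1` gives 9850 nM in a functional assay on SK-BR-3 cells (Homo sapiens) for antiproliferative activity, read by MTT assay, with a stated time of 72 h; a lower number here means a stronger inhibitor, a higher number a weaker inhibitor
compound 2 `CCN1CCN(c2cc(C)c3cc(NC(=O)c4ccc(F)cc4)ccc3n2)CC1` gives 19800 nM in this assay
compound 3 `CCN1CCN(c2cc(C)c3cc(NC(=O)c4ccc(Cl)c(Cl)c4)ccc3n2)CC1` gives 2160 nM in this assay

Compound 3 stands lowest of the three in this assay, with a 4.6-fold lower number from compound 1 to compound 3 (0.66 log units; beyond the scatter) and a 9.2-fold lower number from compound 2 to compound 3 (0.96 log units; beyond the scatter) both beyond the scatter. Compound 4 `CCN1CCN(c2cc(C)c3cc(NC(=O)c4cccc(C)c4)ccc3n2)CC1` is not yet measured; its change from compound 3 is 3-methylphenyl in place of 3,4-dichlorophenyl on a carbonyl carbon. The two measured steps onto the carbonyl carbon, a 4.6-fold lower number from compound 1 to compound 3 (0.66 log units; beyond the scatter) and a 9.2-fold lower number from compound 2 to compound 3 (0.96 log units; beyond the scatter), show that leaving the 3,4-dichlorophenyl for another aryl group went with a higher number, while a 2.0-fold higher number from compound 1 to compound 2 (0.30 log units; within the scatter) shows little spread between the other two aryl groups. A rise of similar size is therefore expected for compound 4, the expected step being a 3.7-fold higher number from compound 3 to compound 4 (0.57 log units; beyond the scatter). Compound 4 is estimated at 8000 nM, between 2500 nM and 25000 nM.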

Compound 4, half-maximal inhibitory concentration: 13700 nM
Compound 4: the middle estimate sits 1.7-fold (0.23 log units) below what was measured; measured number inside the range.
By their numbers in this assay, from the lowest: compound 3; then compounds 1, 4 and 2 (each within the scatter of the next).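

Replacing the 3,4-dichlorophenyl with 3-methylphenyl gives a 6.3-fold higher number from compound 3 to compound 4 (0.80 log units; beyond the scatter) and removes the advantage seen with compound 3. Compound 4 also matches the other two amides, with a 1.4-fold lower number from compound 2 to compound 4 (0.16 log units; within the scatter) and a 1.4-fold higher number from compound 1 to compound 4 (0.14 log units; within the scatter) both small enough that the 3-methylphenyl, 4-fluorophenyl and 4-ethylphenyl groups cannot be told apart here. Among these four aryl groups, only the 3,4-dichlorophenyl stands out, and no available evidence explains why. On these data alone, it remains open whether a single chlorine would keep the lower number, and how an aryl group carrying an amine or a carboxylic acid would behave at this carbonyl carbon.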